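A few compounds are considered here, and "the series" means these few. Any claim that something is new, unique, unknown or untested is made for them only; others in the source may bear on it.

Of the compounds shown here, three share one core and have been tested in an ADME assay on cells (Homo sapiens) for cytotoxicity, read by polymerase chain reaction, with a stated time of 3 days (on this read-out lower numbers stand for higher toxicity in this test and higher numbers for lower toxicity in this test), so far. Compound 1 `CN(C)c1ccc2nc(-c3c(Cl)nc(N)nc3N[C@@H]3C[C@H](CO)[C@@H](O)[C@H]3O)sc2c1` gives only the upper limit of this assay, > 25000 nM, not a number. Compound 2 `Nc1ncc(-c2nc3ccccc3s2)c(N[C@@H]2C[C@H](CO)[C@@H](O)[C@H]2O)n1` likewise gives only that limit, > 25000 nM. Among the compounds with values here, compound 3 `Cc1nc(N)nc(N[C@@H]2C[C@H](CO)[C@@H](O)[C@H]2O)c1-c1nc2ccccc2s1`, with a methyl group on the core, is the one compound here with a real number: in this assay compound 3 gives 4000 nM. Within the data shown here, the single measured step, an at least 6.2-fold lower number from compound 2 to compound 3 (0.79 log units; beyond the scatter), shows that methyl raising toxicity; because two of the three results sit at the limit of > 25000 nM in this assay, at which 2 of the 3 values shown sit, the size of that step is known only as a minimum.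

Compound 4 `Cc1nc(NCCC(F)(F)F)nc(N[C@@H]2C[C@H](CO)[C@@H](O)[C@H]2O)c1-c1nc2ccccc2s1` differs from compound 3 at another place: 3,3,3-trifluoropropyl in place of hydrogen on a nitrogen on an aromatic ring. Among the measured compounds shown here, no measured step touches that nitrogen, so the step from compound 2 to compound 3 does not tell what to expect here. The change leaves the methyl in place and adds a chain that is neither a donor nor an acceptor. With no direct guide, the expectation is a step within or barely beyond the scatter, a 1.6-fold lower number from compound 3 to compound 4 (0.20 log units; within the scatter), leaning toward a slightly lower number. Compound 4 is therefore estimated at 2500 nM in this assay, within 800 nM to 12000 nM.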

Compound 4, half-maximal cytotoxic concentration: 9000 nM
Beside the measured number, compound 4's estimate is 3.6-fold (0.56 log units) below it; the range from low to high includes it.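

Within the data shown here, this is the first look at the nitrogen on an aromatic ring, and it shows that this position tolerates a substituent in this assay: 3,3,3-trifluoropropyl in place of hydrogen gives a 2.3-fold higher number from compound 3 to compound 4 (0.35 log units; beyond the scatter), which points to lower toxicity in this test. The two changes shown so far therefore pull in opposite directions, with the methyl on an aromatic carbon giving an at least 6.2-fold lower number from compound 2 to compound 3 (0.79 log units; beyond the scatter) and the new chain on the nitrogen moving the number back up. The new step also has a real number at both ends, so its size is known, whereas the earlier step ends at a limit: the limit of > 25000 nM in this assay, at which 2 of the 4 values shown sit.

As far as these compounds go, whether the higher number goes with the fluorine atoms, with the length of the chain or simply with replacing that hydrogen stays open, and a plain propyl chain, a shorter ethyl chain or a chain ending in an amine would be needed to tell these apart. Also open, from the compounds shown here alone, is whether 3,3,3-trifluoropropyl would move the number in the same way on a core without the methyl.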